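Trifluoromethoxy for Trifluoromethyl on a Methylbenzimidazole Core

The source may hold more compounds than are shown below. What is called first, only, known or untested is meant among the compounds shown, and "the series" means these compounds.

Compounds 1, 2 and 3 share a core and differ at its two ends. Compound 1 `Oc1cccc2[nH]c(-c3ccc(-c4ccc(-c5ccc(C(F)(F)F)cc5)cc4)cc3)nc12` gives 2260 nM in a functional assay on PC-3 cells (Homo sapiens) for inhibition, read by sulforhodamine B assay; a lower number here means a stronger inhibitor of growth, a higher number a weaker inhibitor of growth. In this assay compound 2 `Oc1cccc2[nH]c(-c3ccc(-c4ccc(-c5ccc(OC(F)(F)F)cc5)cc4)cc3)nc12` gives 7410 nM, and compound 3 `Cc1ccc2[nH]c(-c3ccc(-c4ccc(-c5ccc(C(F)(F)F)cc5)cc4)cc3)nc2c1` gives 2010 nM. The change trifluoromethoxy in place of trifluoromethyl on an aromatic carbon produced a 3.3-fold higher number from compound 1 to compound 2 (0.52 log units; beyond the scatter). The cores of compound 1 and compound 3 differ as 5-methyl-1H-benzimidazol-2-yl in place of 4-hydroxy-1H-benzimidazol-2-yl on an aromatic carbon, which gave a 1.1-fold lower number from compound 1 to compound 3 (0.05 log units; within the scatter). Compound 4 `Cc1ccc2[nH]c(-c3ccc(-c4ccc(-c5ccc(OC(F)(F)F)cc5)cc4)cc3)nc2c1` has not yet been measured in this assay; it differs from compound 3 by trifluoromethoxy in place of trifluoromethyl on an aromatic carbon, the same change as from compound 1 to compound 2, at the same place. Compound 4 is expected to show a 3.3-fold higher number from compound 3 to compound 4 (0.52 log units; beyond the scatter), an expectation that rests on the step of a 3.3-fold higher number from compound 1 to compound 2 (0.52 log units; beyond the scatter) applied to compound 3 with its value 2010 nM. Compound 4 is estimated at 6600 nM, with a range from 3000 nM to 14000 nM.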

Compound 4, concentration for 50% growth inhibition: 2010 nM
The estimate for compound 4 lay 3.3-fold (0.52 log units) above the measured number, outside the stated range (below it).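

In this assay trifluoromethoxy in place of trifluoromethyl gave no change at the digits printed from compound 3 to compound 4 (within the scatter), so the step seen on the core of compound 1 did not carry over to the core of compound 3: the same change on two cores in this assay, a 3.3-fold higher number (0.52 log units; beyond the scatter) from compound 1 to compound 2 and no change at the digits printed (within the scatter) from compound 3 to compound 4, 3.3-fold (0.52 log units) apart, beyond the scatter of two such steps. The core change likewise depended on the end group, giving a 3.7-fold lower number from compound 2 to compound 4 (0.57 log units; beyond the scatter) against a 1.1-fold lower number from compound 1 to compound 3 (0.05 log units; within the scatter): the same change on two cores in this assay, a 1.1-fold lower number (0.05 log units; within the scatter) from compound 1 to compound 3 and a 3.7-fold lower number (0.57 log units; beyond the scatter) from compound 2 to compound 4, 3.3-fold (0.52 log units) apart, beyond the scatter of two such steps. These four compounds show that the two changes do not simply add, but they do not show why, or which step is more typical of the series.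

As far as these compounds go, whether either step would hold on a third core remains open. So does the outcome with an amine or a carboxylic acid in place of trifluoromethyl.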